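The compounds below may be only part of what the source reports. "The series", "measured", "known", "first", "only" and "open" are said of these compounds alone.

Measured compounds:
- compound 1, `O=C1C=CC(OCC(F)(F)F)N1c1cc(F)cc(F)c1`: 520 nM
- compound 2, `Cc1ccc(N2C(=O)C=CC2OCC(F)(F)F)cc1`: 7140 nM

In a functional assay on K562 cells (Homo sapiens) for inhibition (on this read-out lower numbers stand for stronger inhibition and higher numbers for weaker inhibition), compound 1 gives 520 nM, and compound 2 gives 7140 nM. Compound 2 thus stands at the highest of the two numbers; compound 1 has a lower number, and the gap between them is beyond the scatter. For the measured compounds named here, no single-point step between these two compounds is known, so only what their values show can be said.

Compound 3, `O=C1C=CC(OCC(F)(F)F)N1c1ccccc1`, is not yet measured in this assay. It differs from compound 2 by hydrogen in place of methyl on an aromatic carbon, para to a large group. Going by the values given here, nothing among the measured compounds shows what such a change does on this core. The step from compound 2 to compound 3 is therefore expected to be modest, most likely toward a lower number, with a 2.0-fold lower number from compound 2 to compound 3 (0.31 log units; beyond the scatter) as the estimated change. For compound 3 the estimate in this assay is 3500 nM, within a range of 900 nM to 14000 nM.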

Compound 3, half-maximal inhibitory concentration: 24600 nM
Compound 3: middle estimate off by 7.0-fold (0.85 log units), on the low side, outside the stated range (above it).
By their numbers in this assay, from the lowest: compound 1; then compound 2; then compound 3.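

In this assay the first read on this position comes from hydrogen in place of methyl on an aromatic carbon, para to a large group (a 3.4-fold higher number from compound 2 to compound 3 (0.54 log units; beyond the scatter)). The step is beyond the scatter and runs toward weaker inhibition, so on this core the methyl of compound 2 goes with the lower number and its loss is not neutral. Nothing at hand offers an explanation for this step.

Going by these compounds, whether a longer chain such as ethyl, or a methoxy group or an amine at the same place, would go further than methyl remains open. On these data alone, it is also open whether the same change would give a step of similar size on a ring carrying the fluorine atoms of compound 1.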